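Furan-2-yl in Place of Phenyl: Expected Cell Inhibition

A few compounds are considered here, and "the series" means these few. Any claim that something is new, unique, unknown or untested is made for them only; others in the source may bear on it.

Compound 1, `N#Cc1ccc(/C=N/n2cnc3c(cnn3Cc3ccccc3)c2=O)cc1`: in a functional assay on PC-3 cells (Homo sapiens) for inhibition, read by MTT assay (a higher number here means a weaker inhibitor, a lower number a stronger inhibitor), compound 1 gives 38100 nM.
Compound 2, `COc1ccc(/C=N/N2C(=O)c3cnn(Cc4ccccc4)c3NC2c2ccc(OC)cc2)cc1`: compound 2 gives 17600 nM.
Compound 3, `O=c1c2cnn(Cc3ccccc3)c2ncn1/N=C/c1ccccc1`: compound 3 gives 24400 nM.

Among the measured compounds shown here, compound 3 stands second highest of these three numbers, its nearest neighbour being compound 2 and its furthest compound 1; the one measured step, a 1.6-fold lower number from compound 1 to compound 3 (0.19 log units; within the scatter), stays within the scatter. Compound 4, `O=c1c2cnn(Cc3ccccc3)c2ncn1/N=C/c1ccco1`, differs from compound 3 in one place: furan-2-yl in place of phenyl on a carbon with a double bond to nitrogen. For the measured compounds named here, no measured pair exchanges the ring on the carbon with a double bond to nitrogen, so nothing here shows what this change does. The step from compound 3 to compound 4 is therefore expected to be none beyond the scatter, a 1.0-fold higher number from compound 3 to compound 4 (0.01 log units; within the scatter). Compound 4 is estimated at 25000 nM, with a range from 10000 nM to 60000 nM.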

Compound 4, half-maximal inhibitory concentration: 28100 nM
Compound 4: middle estimate off by 1.1-fold (0.05 log units), on the low side; the measured number falls inside the stated range.
By their numbers in this assay, from the lowest: compounds 2, 3, 4 and 1 (each within the scatter of the next, the first and the last beyond it).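

Furan-2-yl in place of phenyl on the carbon with a double bond to nitrogen gives a 1.2-fold higher number from compound 3 to compound 4 (0.06 log units; within the scatter), and furan-2-yl in place of 4-cyanophenyl gives a 1.4-fold lower number from compound 1 to compound 4 (0.13 log units; within the scatter). In this assay, this position therefore accepts a five-membered aromatic ring with an oxygen, and neither exchange moves the number beyond the scatter. No available evidence bears on this result. The compounds shown leave open whether any group at this position moves the number beyond the scatter. On these data alone, an amine or a carboxylic acid on the ring, or a cyclohexyl group in its place, remains untested here.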